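Cyano on the phenyl of a piperazine dithiocarbamate benzamide

The source may report more compounds than this note shows. Statements on the series, on what has been measured and on what is new or still open speak of the compounds shown alone.

The shared core of this small set is shown by compound 1, `Nc1ccccc1NC(=O)c1ccc(CSC(=S)N2CCN(C(c3ccccc3)c3ccccc3)CC2)cc1`, and compound 2, `Nc1ccccc1NC(=O)c1ccc(CSC(=S)N2CCN(c3ccccc3)CC2)cc1`. In a functional assay on MGC-803 cells (Homo sapiens) for antiproliferative activity, read by CCK-8 assay, with a stated time of 72 h, tested at 2 uM (on this read-out lower numbers stand for a weaker effect and higher numbers for a stronger effect at the one concentration tested), compound 1 gives 9.8%. In this assay compound 2 gives 42.3%, the highest of the two numbers available; its nearest neighbour, compound 1, lies beyond the scatter below it. Among the measured compounds shown here, no step between these two measured compounds has been computed, so only their two values are set side by side here.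

Compound 3, `N#Cc1ccc(N2CCN(C(=S)SCc3ccc(C(=O)Nc4ccccc4N)cc3)CC2)cc1`, has not yet been measured. It differs from compound 2 in one place: cyano in place of hydrogen on an aromatic carbon, on an aromatic carbon of a six-membered aromatic ring of carbon only, para to a large group. Nothing measured in this set tells how such a change shifts the number in this assay. The step from compound 2 to compound 3 is therefore expected to be small, around or within the scatter, with no clear direction, as a number 2.7 percentage points higher from compound 2 to compound 3 (within the scatter). For compound 3 the estimated value in this assay is 45%, lying between 20% and 70%.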

Compound 3, a percentage reported as inhibition, at one concentration (the size of the read-out at that concentration, not a potency): 34.5%
Compound 3: middle estimate off by 10.5 percentage points, on the high side; measured number inside the range.
By their numbers in this assay, from the lowest: compound 1; then compounds 3 and 2 (each within the scatter of the next).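

Phenyl to 4-cyanophenyl is the first change in this set that can be read as a single step, and in this assay it comes to a number 7.8 percentage points lower from compound 2 to compound 3 (within the scatter) at the one concentration tested. This aromatic carbon, para to a large group, therefore accepts cyano in place of hydrogen without a shift that stands clear of the usual scatter, and compound 3 cannot be told apart from compound 2 on this read-out. Nothing available bears on the reason for this outcome.

The compounds shown leave open whether a different group on the same aromatic carbon, such as an amine, a carboxylic acid, a methoxy group or a fluorine atom, would also leave the number within the scatter or would move it clearly in either direction. They also leave open whether compound 2 and compound 3 would stay this close at other concentrations or in other cell lines, since a single step at a single concentration gives no measure of potency.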